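Chain shortening from compound 2 to compound 4

This account rests on a few compounds, and the source may have more. Where it says the series, first, only, none or still open, it means among the compounds named here.

Compound 2 (`CCCCCCCC(=O)Oc1cc(C(=O)C2=C3OC(C)(C)[C@@H](CC=C(C)C)C[C@@]34C[C@@H](CC=C(C)C)C(C)(C)[C@H]3CCC(C)(C)O[C@]34OC2=O)ccc1O`) reads > 20000 nM in a functional assay on MCF7 cells (Homo sapiens) for antiproliferative activity, read by MTT assay, with a stated time of 72 h (on this read-out higher numbers stand for weaker inhibition and lower numbers for stronger inhibition), and this is a limit of the assay, not a number. Compound 1 (`COc1ccc(C(=O)Oc2ccc(C(=O)C3=C4OC(C)(C)[C@@H](CC=C(C)C)C[C@@]45C[C@@H](CC=C(C)C)C(C)(C)[C@H]4CCC(C)(C)O[C@]45OC3=O)cc2OC(=O)c2ccc(OC)cc2)cc1`) reads > 20000 nM in this assay and this is also a limit. Compound 2 therefore belongs with the limit of > 20000 nM in this assay, at which 2 of the 3 values shown sit, and has no number of its own. Among the compounds with values here, compound 3 (`CC(=O)Oc1ccc(C(=O)C2=C3OC(C)(C)[C@@H](CC=C(C)C)C[C@@]34C[C@@H](CC=C(C)C)C(C)(C)[C@H]3CCC(C)(C)O[C@]34OC2=O)cc1OC(C)=O`) gives a measured 4830 nM in this assay as the only number so far. Compound 4 (`CCCCCC(=O)Oc1cc(C(=O)C2=C3OC(C)(C)[C@@H](CC=C(C)C)C[C@@]34C[C@@H](CC=C(C)C)C(C)(C)[C@H]3CCC(C)(C)O[C@]34OC2=O)ccc1O`) differs from compound 2 by hydrogen in place of ethyl on a saturated chain carbon, five bonds along the chain from a carbonyl carbon with hydrogen in place of ethyl on a saturated chain carbon, five bonds along the chain from a carbonyl carbon. Little change is expected: the estimated step of an at least 1.2-fold lower number from compound 2 to compound 4 (0.09 log units; that floor lies within the scatter) leans slightly towards stronger inhibition and stays within the usual scatter. For compound 4 the estimate is 16000 nM with an expected range from 6000 nM to 40000 nM in this assay and a result at the limit remains likely.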

Compound 4, half-maximal inhibitory concentration: 15500 nM
Beside the measured number, compound 4's estimate is 1.0-fold (0.01 log units) above it, within the range that was stated.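

Hydrogen in place of ethyl on a saturated chain carbon, five bonds along the chain from a carbonyl carbon, gives in this assay an at least 1.2-fold lower number from compound 2 to compound 4 (0.11 log units; that floor lies within the scatter). Compound 4 gives this chain ester its first number, 15500 nM. The true size of the step stays unknown, as compound 2 is a limit and not a number: the limit of > 20000 nM in this assay, at which 2 of the 4 values shown sit.

Open, as far as these compounds go, is how a still shorter chain on the same ester would read against compound 4. Also open, from the compounds shown here alone, is how an amine or a carboxylic acid in place of the chain would read.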